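The source may report more compounds than this note shows. Statements on the series, on what has been measured and on what is new or still open speak of the compounds shown alone.

In an assay for inhibition of 6-phosphofructo-2-kinase/fructose-2,6-bisphosphatase 3 (Homo sapiens), read by ADP-Glo, with a stated time of 2 h (on this read-out lower numbers stand for stronger inhibition and higher numbers for weaker inhibition), compound 1 `Cn1ccc2ccc(-c3cc(Nc4cnccc4C(=O)NCc4cncnc4)cc4nccnc34)cc21` gives 106 nM, and compound 2 `Cn1cc(NC(=O)c2ccncc2Nc2cc(-c3ccc4ccn(C)c4c3)c3nccnc3c2)cn1` gives 33 nM. The two share a common core and differ only on the amide-type nitrogen, where the step of a 3.2-fold lower number from compound 1 to compound 2 (0.51 log units; beyond the scatter) shows that the 1-methyl-1H-pyrazol-4-yl amide is the more potent of the pair. On the numbers shown, compound 2 therefore stands lowest in this assay, with compound 1 as its only and weaker neighbour.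

Compound 3 `CN1CCC(NC(=O)c2ccncc2Nc2cc(-c3ccc4ccn(C)c4c3)c3nccnc3c2)CC1` is not yet measured in this assay. It differs from compound 2 in one place: 1-methylpiperidin-4-yl in place of 1-methyl-1H-pyrazol-4-yl on an amide-type nitrogen. Going by the values given here, the only measured step, a 3.2-fold lower number from compound 1 to compound 2 (0.51 log units; beyond the scatter), also changes the group on the amide-type nitrogen, but it replaces one aromatic heterocycle by another, so it bears on the present change only loosely; no step shows what a saturated ring at this position does. The author therefore expects no clear move beyond the scatter, with a slight lean toward a weaker number, and estimates for compound 3 a step of a 1.5-fold higher number from compound 2 to compound 3 (0.18 log units; within the scatter) in this assay, giving an estimated value of 50 nM with a range from 15 nM to 170 nM.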

Compound 3, half-maximal inhibitory concentration: 38 nM
For compound 3 the middle estimate is 1.3-fold (0.12 log units) above the measured one; low and high end bracket the measured number.
By their numbers in this assay, from the lowest: compounds 2 and 3 (each within the scatter of the next); then compound 1.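

In this assay, the step of a 1.2-fold higher number from compound 2 to compound 3 (0.06 log units; within the scatter) shows that an aromatic ring is not needed on this amide-type nitrogen: the six-membered non-aromatic 1-methylpiperidin-4-yl and the five-membered aromatic 1-methyl-1H-pyrazol-4-yl give values within the scatter of each other, a comparison the earlier pair could not offer. The step of a 2.8-fold lower number from compound 1 to compound 3 (0.45 log units; beyond the scatter) then places (pyrimidin-5-yl)methyl apart from both other groups, so that among these three compounds the group with the higher number is the one that carries an aromatic ring on a methylene link, while rings of quite different kinds attached directly to the nitrogen read alike. No measurement given here accounts for this result.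

The compounds shown leave open whether the ring nitrogen or its methyl group in 1-methylpiperidin-4-yl plays any part in the value, which a plain cyclohexyl group or an unsubstituted piperidin-4-yl would test. They also leave open how far this freedom extends, for instance to an open chain such as a 2-(dimethylamino)ethyl group on the same nitrogen.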